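Extending the benzyloxy chain toward a pyridylpropoxy group

A few compounds are considered here, and "the series" means these few. Any claim that something is new, unique, unknown or untested is made for them only; others in the source may bear on it.

Compound 1 `CCCCOc1cc(CCc2nc(C)c(CC)s2)nc(NCc2cc(Cl)cc(NC(=O)OC(C)C)c2)c1` gives 16 nM in an assay on cells for binding affinity to Neuropeptide Y receptor type 1 (Homo sapiens); a lower number here means a stronger inhibitor, a higher number a weaker inhibitor. Compound 2 `CCc1sc(CCc2cc(OCc3ccccc3)cc(NCc3cc(Cl)cc(NC(=O)OC(C)C)c3)n2)nc1C` gives 237 nM and so stands with the highest of the two numbers measured, its nearest neighbour being compound 1, which differs only by propyl rather than phenyl on the saturated chain carbon bound to the oxygen on the aromatic ring; that change reads a 15-fold higher number from compound 1 to compound 2 (1.17 log units; beyond the scatter).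

Compound 3 `CCc1sc(CCc2cc(OCCCc3cccnc3)cc(NCc3cc(Cl)cc(NC(=O)OC(C)C)c3)n2)nc1C` is not yet measured. It differs from compound 2 by 2-(pyridin-3-yl)ethyl in place of phenyl on a saturated chain carbon bound to an oxygen on an aromatic ring. For the measured compounds named here, the only step that bears on this place is the one from compound 1 to compound 2, where replacing a chain by a single phenyl carried a large penalty. Going by the values given here, compound 3 reinstates a chain of similar length to that of compound 1 while keeping an aromatic ring at its end, so part of that penalty is expected to be recovered, though not necessarily all of it, since no compound with both features has been measured.

The step from compound 2 to compound 3 is therefore expected to be a 4.0-fold lower number from compound 2 to compound 3 (0.60 log units; beyond the scatter), and compound 3 is estimated at 60 nM, within a range of 18 nM to 200 nM.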

Compound 3, half-maximal inhibitory concentration: 6.5 nM
Compound 3: the middle estimate sits 9.2-fold (0.97 log units) above what was measured; the measured number lies below the stated range.
By their numbers in this assay, from the lowest: compound 3; then compound 1; then compound 2.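

Working notes on the chain at the oxygen on the aromatic ring: in this assay, an aromatic ring at this place is not in itself penalised, since the change from benzyloxy to 3-(pyridin-3-yl)propoxy gives a 36-fold lower number from compound 2 to compound 3 (1.56 log units; beyond the scatter) and so more than reverses the loss seen in a 15-fold higher number from compound 1 to compound 2 (1.17 log units; beyond the scatter). The ring-bearing chain also improves on the all-carbon chain, with pyridin-3-yl in place of the terminal methyl giving a 2.5-fold lower number from compound 1 to compound 3 (0.39 log units; beyond the scatter), a modest step but beyond the scatter, and this makes compound 3 the strongest of the three in this assay. No accompanying measurement accounts for either step.

Still open, from the compounds shown here alone, is whether the gain follows the longer link to the ring or the ring nitrogen, a question that 3-phenylpropoxy at the same place would separate. Also open, going by these compounds, is how far the position tolerates other chain ends and lengths, such as pyridin-4-yl, a terminal morpholine or a 4-(pyridin-3-yl)butoxy chain.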